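Cytotoxicity limits across sulfonamide piperidines

The source may hold more compounds than are shown below. What is called first, only, known or untested is meant among the compounds shown, and "the series" means these compounds.

compound 1, `CC1CCN(C2CCN(S(=O)(=O)c3cccnc3F)CC2)CC1`, in an ADME assay on HCT-116 cells (Homo sapiens) for cytotoxicity, read by CellTiter-Glo, with a stated time of 72 h; a higher number here means a weaker inhibitor, a lower number a stronger inhibitor: > 10000 nM, a limit of the assay
compound 2, `Cc1cc(C)c(S(=O)(=O)N2CCC(N3CC(C)CC(C)C3)CC2)c(C)c1`, in this assay: > 5000 nM, a limit of the assay
compound 3, `CC1CCN(C2CCN(S(=O)(=O)c3ccccc3-c3ccccc3)CC2)CC1`, in this assay: > 5000 nM, a limit of the assay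

Compound 1 stands only at a limit in this assay, as shown by the limit of > 10000 nM in this assay, at which 1 of the 3 values shown sits. Compound 2 and compound 3 likewise stop at a limit, as shown by the limit of > 5000 nM in this assay, at which 2 of the 3 values shown sit. Among the measured compounds shown here, no step between measured compounds is available, so no measured change in this assay can be weighed. Compound 4 `CC1CCN(C2CCN(S(=O)(=O)c3ccc(Cl)c(Cl)c3)CC2)CC1` differs from compound 1 by 3,4-dichlorophenyl in place of 2-fluoropyridin-3-yl on a sulfonyl sulfur. Because compound 1 rests at a limit (the limit of > 10000 nM in this assay, at which 1 of the 3 values shown sits), the step of a number no higher from compound 1 to compound 4 (the limit leaves the size open) is expected to stay within the scatter. Compound 4 is thus expected near 10000 nM, in a range from 3000 nM to 30000 nM.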

Compound 4, half-maximal inhibitory concentration: > 5000 nM
Compound 4: a limit, no number; the forecaster's own chance of this, stated with the estimate: 75%; the middle value lies beyond the limit too.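

Compound 1 and compound 4 both stop at a limit of the assay, so the step between them cannot be read. The compounds shown leave open at what concentration any of them would reach half-maximal inhibition in this assay.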